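Swapping Fluorophenyl for Naphthyl on a Thiourea Amide

The source may hold more compounds than are shown below. What is called first, only, known or untested is meant among the compounds shown, and "the series" means these compounds.

Compound 1, `NC(=S)N1CCCc2c(OCCCCCOc3cccc4ccccc34)cccc21`, was tested in an ADME assay on Huh-7 cells (Homo sapiens) for cytotoxicity (a higher number here means that more compound is tolerated, a lower number that less compound is tolerated), and gave > 50000 nM, which is a limit of the assay rather than a number. For the measured compounds named here, compound 2, `O=C(NC(=S)N1CCc2c(OCCCCCOc3ccc(Cl)cc3)cccc21)c1ccc(F)cc1`, in this assay gives 31100 nM, the only actual number among the two results gathered so far; the other result sits at the limit of > 50000 nM in this assay, at which 1 of the 2 values shown sits. Compound 3, `O=C(NC(=S)N1CCc2c(OCCCCCOc3ccc(Cl)cc3)cccc21)c1ccc2ccccc2c1`, has not yet been measured. It differs from compound 2 in one place: naphthalen-2-yl in place of 4-fluorophenyl on a carbonyl carbon. Going by the values given here, no step between two measured compounds is available, so the size of this change cannot be read from anything already seen. The expected step from compound 2 to compound 3 is small, a 1.6-fold lower number from compound 2 to compound 3 (0.19 log units; within the scatter), leaning toward slightly less compound being tolerated, though not clearly beyond the usual scatter. For compound 3 the estimate in this assay is 20000 nM, with a range from 8000 nM to 50000 nM.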

Compound 3, half-maximal cytotoxic concentration: > 50000 nM
Compound 3: a limit, no number; the forecaster's own chance of this, stated with the estimate: 20%; middle value at least 2.5-fold (0.39 log units) from the limit.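

The change of group on the carbonyl carbon gives, in this assay, an at least 1.6-fold higher number from compound 2 to compound 3 (0.20 log units; that floor lies within the scatter). For the compounds shown here, this is the first step that can be read at this position, and it shows that the second aromatic ring brings no sign of less compound being tolerated. Compound 3 gives a limit and not a number, so the step is only a floor, and this limit is now shared with another compound: the limit of > 50000 nM in this assay, at which 2 of the 3 values shown sit.

From the compounds shown here alone, how far compound 3 really lies from compound 2 stays open, and so does whether the change exceeds the usual scatter. Also open, going by these compounds, is how a pyridine ring, a carboxylic acid or a simple methyl on this carbonyl carbon would behave in this assay.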